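The source may hold more compounds than are shown below. What is called first, only, known or untested is meant among the compounds shown, and "the series" means these compounds.

Measured in an ADME assay on MT4 cells (Homo sapiens) for cytotoxicity, read by MTT assay, with a stated time of 96 h; on this read-out lower numbers stand for higher toxicity in this test and higher numbers for lower toxicity in this test:

Compound 1 `Cc1ccc(NCc2cn(-c3ccccc3)nc2-c2ccc(Cl)cc2)cc1`: > 100000 nM (a limit of the assay)
Compound 2 `FC(F)(F)c1ccc(NCc2cn(-c3ccccc3)nc2-c2ccccc2)cc1`: > 100000 nM (a limit of the assay)

Neither compound has a number yet. Compound 2 stands only at the limit > 100000 nM, and it shares that position with compound 1, as the record shows: the limit of > 100000 nM in this assay, at which 2 of the 2 values shown sit.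

The next compound to be tested is compound 3 `FC(F)(F)c1ccc(NCc2cn(-c3ccccc3)nc2-c2ccc(Cl)cc2)cc1`. It differs from compound 2 by chloro in place of hydrogen on an aromatic carbon, para to a large group, so that phenyl becomes 4-chlorophenyl: chloro in place of hydrogen on an aromatic carbon.

Among the measured compounds shown here, no measured step between two compounds is available in this assay, so the size of this change cannot be read from the data. The expectation rests only on compound 1 and compound 2 both sitting at the limit: the limit of > 100000 nM in this assay, at which 2 of the 2 values shown sit. No step beyond the scatter is expected, and any number that does appear should lie on the lower side of the limit. The estimated change is a number no higher from compound 2 to compound 3 (the limit leaves the size open).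

For compound 3 the expected value is 100000 nM, with an estimated range from 35000 nM to 100000 nM.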

Compound 3, half-maximal cytotoxic concentration: > 100000 nM
Compound 3: a limit, no number (the forecaster's own chance of this, stated with the estimate: 75%); the middle value sits exactly at the limit.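

In this assay compound 3 gives > 100000 nM as a limit of the assay and not a number. The steps to compound 3 from compound 1 and compound 2 cannot be read, since all three compounds stand at the same limit: the limit of > 100000 nM in this assay, at which 3 of the 3 values shown sit. The compounds shown leave open whether chloro in place of hydrogen, or trifluoromethyl in place of methyl, changes this read-out at all.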